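Methyl in place of hydrogen on the pendant phenyl

The source may report more compounds than this note shows. Statements on the series, on what has been measured and on what is new or still open speak of the compounds shown alone.

Measured so far:
compound 1, `COc1cc2c(Oc3ccc(NC(=O)c4cc(-c5ccccc5)ccn4)cc3F)ccnc2cc1OCCCN1CCN(C)CC1`, 340 nM
compound 2, `COc1cc2c(Oc3ccc(NC(=O)c4cc(-c5ccc(C(F)(F)F)cc5)ccn4)cc3F)ccnc2cc1OCCCN1CCCCC1`, 1640 nM

Within the data shown here, in a functional assay on A549 cells (Homo sapiens) for cytotoxicity, read by MTT assay, with a stated time of 72 h (a lower number here means a stronger inhibitor, a higher number a weaker inhibitor), compound 1 gives 340 nM, the lower of the two numbers so far. Among the measured compounds shown here, compound 2 differs from compound 1 in more than one place, and the two values show compound 2 at the higher number; no single step between them can be read from that pair.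

Compound 3, `COc1cc2c(Oc3ccc(NC(=O)c4cc(-c5ccccc5C)ccn4)cc3F)ccnc2cc1OCCCN1CCN(C)CC1`, is not yet measured. It differs from compound 1 by one change: methyl in place of hydrogen on an aromatic carbon. For the measured compounds named here, nothing in the two measured compounds isolates this change, so there is no measured step to lean on.

The expectation is that the step from compound 1 to compound 3 stays small, with a 1.5-fold higher number from compound 1 to compound 3 (0.17 log units; within the scatter) in this assay, most likely toward a slightly higher number but possibly within the scatter. Compound 3 is estimated at 500 nM, with a range from 150 nM to 1700 nM; the range is wide because compound 1 with 340 nM is the only direct anchor.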

Compound 3, half-maximal inhibitory concentration: 1330 nM
Compound 3: middle estimate off by 2.7-fold (0.42 log units), on the low side; low and high end bracket the measured number.
By their numbers in this assay, from the lowest: compound 1; then compounds 3 and 2 (each within the scatter of the next).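

In this assay, among these compounds, the change from phenyl to 2-methylphenyl gives a 3.9-fold higher number from compound 1 to compound 3 (0.59 log units; beyond the scatter) and is the first single change that can be read; compound 2 differs from compound 1 and compound 3 in more than one place, so no step to it can be read. The result shows that this carbon of the pendant phenyl, ortho to a large group, is not indifferent to substitution: one added methyl, with the rest of compound 1 held fixed, is enough to give a weaker inhibitor by a margin beyond the scatter. Nothing available on these compounds bears on the reason for this step.

Still open, from the compounds shown here alone, is whether the step belongs to methyl specifically or would follow any group on this carbon, a question that a methoxy, an amine or a hydroxyl at the same place would address. Also open, going by these compounds, is whether the same methyl on the other carbons of the phenyl gives a step of similar size, or whether the effect is confined to the place ortho to the large group.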